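Replacing phenyl with ethynyl at the assay limit

The source may hold more compounds than are shown below. What is called first, only, known or untested is meant among the compounds shown, and "the series" means these compounds.

In a functional assay on HeLa S3 cells (Homo sapiens) for antiproliferative activity, read by XTT assay, with a stated time of 72 h (on this read-out higher numbers stand for weaker inhibition and lower numbers for stronger inhibition), compound 1 (`CNc1ncnc2c1c(-c1ccoc1)cn2[C@@H]1O[C@H](CO)[C@@H](O)[C@H]1O`) reads > 20000 nM as a limit of the assay. Compound 2 (`CNc1ncnc2c1c(-c1ccccc1)cn2[C@@H]1O[C@H](CO)[C@@H](O)[C@H]1O`) also stands only at a limit, > 20000 nM in the same read-out. Among the measured compounds shown here, the one measured change is a step that the two limits leave unreadable from compound 1 to compound 2 and offers no size to carry forward, so the sole evidence is the limit of > 20000 nM in this assay, at which 2 of the 2 values shown sit, for this series. Compound 3 (`C#Cc1cn([C@@H]2O[C@H](CO)[C@@H](O)[C@H]2O)c2ncnc(NC)c12`) has ethynyl in place of phenyl on an aromatic carbon. The expected move is an at least 1.6-fold lower number from compound 2 to compound 3 (0.22 log units; that floor lies within the scatter) as estimated, a tentative one toward stronger inhibition. In this assay the estimate for compound 3 is 12000 nM with an expected range from 1000 nM to 30000 nM overall.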

Compound 3, half-maximal inhibitory concentration: > 20000 nM
Compound 3: no number, only a limit; the forecaster's own chance of this, stated with the estimate: 55%; middle value at least 1.6-fold (0.22 log units) from the limit.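

Among the compounds shown here, compound 3 stands at a limit, as compound 1 and compound 2 do, so no step among the three can be read: the limit of > 20000 nM in this assay, at which 3 of the 3 values shown sit. The compounds shown leave open whether any group on this aromatic carbon gives a readable number.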